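A few compounds are considered here, and "the series" means these few. Any claim that something is new, unique, unknown or untested is made for them only; others in the source may bear on it.

Measured compounds and their values in this test:

- compound 1 `CC1(Cc2ccc(/C(N)=N/O)cc2)CC(S(=O)(=O)c2ccc(F)cc2)=C(c2ccc(/C(N)=N/O)cc2)O1`: 42200 nM
- compound 2 `CC1(Cc2cc(C(F)(F)F)cc(C(F)(F)F)c2)CC(S(=O)(=O)c2ccc(F)cc2)=C(c2ccc(/C(N)=N/O)cc2)O1`: 43100 nM

In an ADME assay on cells (Peritoneal macrophage, Mus musculus, strain Balb/c) for cytotoxicity, read by resazurin assay, with a stated time of 72 h (on this read-out lower numbers stand for higher toxicity in this test and higher numbers for lower toxicity in this test), compound 1 gives 42200 nM, the lower of the two numbers in hand. Compound 2 gives 43100 nM in this assay, which sits within the scatter of compound 1, so the two are read as the same. Compound 2 carries a different group on the benzyl side of the shared core than compound 1 does, and that exchange leaves the read-out unchanged within the scatter.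

Compound 3 `CC1(Cc2ccc([N+](=O)[O-])cc2)CC(S(=O)(=O)c2ccc(F)cc2)=C(c2ccc(/C(N)=N/O)cc2)O1` has not been measured in this assay. Relative to compound 1 the change is a group of 3 heavy atoms (1 nitrogen, 2 oxygen; no ring) in place of a group of 4 heavy atoms (1 carbon, 2 nitrogen, 1 oxygen; no ring), on an aromatic carbon. Both measured compounds differ from each other at this same position of the core, and the values of compound 1 and compound 2 show no separation beyond the scatter. The expectation for compound 3 in this assay is therefore a step of a 1.0-fold lower number from compound 1 to compound 3 (0.00 log units; within the scatter) from compound 1, no change beyond the scatter in either direction. Compound 3 is estimated at 42000 nM, with a range from 20000 nM to 85000 nM.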

Compound 3, half-maximal cytotoxic concentration: 97400 nM
The estimate for compound 3 lay 2.3-fold (0.37 log units) below the measured number, outside the stated range (above it).
By their numbers in this assay, from the lowest: compounds 1 and 2 (each within the scatter of the next); then compound 3.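

In this assay, nitro in place of the group of 4 heavy atoms (1 carbon, 2 nitrogen, 1 oxygen), on an aromatic carbon para to a large group, gives a 2.3-fold higher number from compound 1 to compound 3 (0.36 log units; beyond the scatter) as a modest step beyond the scatter, in the direction of lower toxicity in this test. The earlier values showed no separation, whereas this single exchange shows that the read-out can respond to a change at this position, although only by a modest step. The exchange also goes from 2 hydrogen-bond donors to 0 with the count of hydrogen-bond acceptors unchanged, but no available data link that difference to the step, and no measurement bears on why the number rises.

A single exchange cannot show whether the step follows from the arrival of nitro or from the loss of the group it replaces, and an amine, a carboxylic acid or a nitrile in the same place would help to separate the two. Also open, going by these compounds, is whether nitro gives a step of similar size when the rest of the shared core is changed.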